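Benzylthio to cyclohexylmethylthio to trifluoromethylbenzylthio: one series, one step

The compounds below may be only part of what the source reports. "The series", "measured", "known", "first", "only" and "open" are said of these compounds alone.

Measured so far:
compound 1 `Cc1cc(N2CC[C@@H](C)[C@@H](N(C)c3ncnc4[nH]ccc34)C2)n2nc(SCc3ccccc3)nc2n1`, 13900 nM
compound 2 `Cc1nc2nc(SCc3ccc(Cl)cc3)nn2c(N2CC[C@@H](C)[C@@H](N(C)c3ncnc4[nH]ccc34)C2)c1C`, > 100000 nM
compound 3 `Cc1cc(N2CC[C@@H](C)[C@@H](N(C)c3ncnc4[nH]ccc34)C2)n2nc(SCC3CCCCC3)nc2n1`, 11500 nM

All three carry the same core and differ at the group on the sulfur. In a functional assay on HGC-27 cells (Homo sapiens) for inhibition, read by MTT assay, with a stated time of 72 h (on this read-out higher numbers stand for weaker inhibition and lower numbers for stronger inhibition), compound 1 gives 13900 nM. For compound 2 this assay reports only a limit, > 100000 nM, and no number (the limit of > 100000 nM in this assay, at which 1 of the 3 values shown sits). Compound 3 gives 11500 nM in this assay, the lowest of the two numbers shown, with compound 1 nearest; the two lie within the scatter of each other.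

For the measured compounds named here, the single measured step is a 1.2-fold lower number from compound 1 to compound 3 (0.08 log units; within the scatter); exchanging an aromatic ring for a saturated one at that position left the read-out where it was.

Compound 4 `Cc1cc(N2CC[C@@H](C)[C@@H](N(C)c3ncnc4[nH]ccc34)C2)n2nc(SCc3ccc(C(F)(F)F)cc3)nc2n1` is not yet measured. It differs from compound 3 thus: 4-(trifluoromethyl)phenyl in place of cyclohexyl on a saturated chain carbon bound to a sulfur. Going by the values given here, since the phenyl-to-cyclohexyl exchange moved nothing beyond the scatter, a step of similar size is expected here, with no clear direction; the trifluoromethyl adds a further change that no measured pair isolates. Compound 4 is therefore estimated at 18000 nM, between 7000 nM and 60000 nM, which means an expected step of a 1.6-fold higher number from compound 3 to compound 4 (0.19 log units; within the scatter).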

Compound 4, half-maximal inhibitory concentration: 9540 nM
The estimate for compound 4 lay 1.9-fold (0.28 log units) above the measured number; low and high end bracket the measured number.
By their numbers in this assay, from the lowest: compounds 4, 3 and 1 (each within the scatter of the next). At a limit, above all of these: compound 2.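

Notes on the group on the sulfur: in this assay the direct trifluoromethyl-for-hydrogen exchange gives a 1.5-fold lower number from compound 1 to compound 4 (0.16 log units; within the scatter) and is the first measured pair to isolate that change. The exchange of cyclohexyl for 4-(trifluoromethyl)phenyl gives a 1.2-fold lower number from compound 3 to compound 4 (0.08 log units; within the scatter) and brings in a group of 10 heavy atoms in place of one of 6. Phenyl, cyclohexyl and 4-(trifluoromethyl)phenyl on the saturated chain carbon bound to a sulfur thus all sit within the scatter of one another, so neither ring type nor the added trifluoromethyl separates these compounds.

As far as these compounds go, whether an amine or a carboxylic acid in place of the trifluoromethyl would move the number beyond the scatter stays open. Compound 2 differs from compound 1 in more than one place and gives only a limit, so the effect of its 4-chlorobenzyl group cannot be read on its own: the limit of > 100000 nM in this assay, at which 1 of the 4 values shown sits.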